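Sulfonamide aryl swap on the shared core: compound 2 to compound 4

A few compounds are considered here, and "the series" means these few. Any claim that something is new, unique, unknown or untested is made for them only; others in the source may bear on it.

Of the compounds shown here, three have been tested in an assay on cells for inhibition of HSP60/HSP10 (Homo sapiens), with a stated time of 60 min; a lower number here means a stronger inhibitor, a higher number a weaker inhibitor. Compound 1 `CS(=O)(=O)Nc1ccc(-c2nc3cc(NS(=O)(=O)c4ccc(Cl)s4)ccc3o2)cc1` gives 43000 nM in this assay. Compound 3 `O=S(=O)(Nc1ccc(-c2nc3ccccc3o2)cc1)c1ccc(O)cc1` gives 78000 nM in this assay. For compound 2 `Cc1ccccc1S(=O)(=O)Nc1ccc2oc(-c3ccccc3)nc2c1` this assay reports only a limit, > 100000 nM. That is the limit of > 100000 nM in this assay, at which 1 of the 3 values shown sits, so compound 2 stands at the weak end of what is shown and has no number of its own. Compound 4 `CCc1ccc(S(=O)(=O)Nc2ccc3oc(-c4ccccc4)nc3c2)cc1` is not yet measured and carries the change (4-ethylphenyl in place of 2-methylphenyl on a sulfonyl sulfur). Within the data shown here, no step between measured compounds is available to size this change; since the single six-membered aromatic ring of carbon only on the sulfonyl sulfur is retained, no step beyond the scatter is expected, and the expected shift is a number no higher from compound 2 to compound 4 (the limit leaves the size open). Compound 4 is estimated at 100000 nM, in the range 40000 nM to 250000 nM, with a fair chance that this assay again returns only a limit.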

Compound 4, half-maximal inhibitory concentration: > 100000 nM
Compound 4: no number, only a limit; the forecaster's own chance of this, stated with the estimate: 60%; the middle value lies on the limit itself.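

Compound 2 and compound 4 are both only limits in this assay, so no step between them can be read: the limit of > 100000 nM in this assay, at which 2 of the 4 values shown sit.

As far as these compounds go, whether any group on the sulfonyl sulfur of this shared core gives a measurable number in this assay stays open.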